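The compounds below may be only part of what the source reports. "The series", "measured", "known", "first", "only" and "open" are said of these compounds alone.

Compound 1 `Clc1ccc(Sc2c(-c3ccc(Br)cc3)[nH]c3ccccc23)cc1` is tested in a functional assay on U-373MG ATCC cells (Homo sapiens) for inhibition, read by MTT assay, with a stated time of 72 h (a lower number here means a stronger inhibitor of growth, a higher number a weaker inhibitor of growth), and gives 24000 nM. Compound 2 `CCOC(=O)C1CCN(C(=S)Sc2c(-c3ccc(Br)cc3)[nH]c3ccccc23)CC1`, which in this assay gives 35000 nM, lies within the usual scatter of compound 1, so the two cannot be set in order. Compound 3 `Clc1ccc(Sc2c(-c3ccc(Cl)cc3)[nH]c3ccccc23)cc1` differs from compound 1 by a single exchange: chloro in place of bromo on an aromatic carbon. Among the compounds with values here, no measured pair here shows what such an exchange does, so the step is expected to stay within the scatter, namely a 1.0-fold higher number from compound 1 to compound 3 (0.02 log units; within the scatter), with no clear direction. Compound 3 is therefore estimated to give 25000 nM in this assay, within a range from 10000 nM to 60000 nM.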

Compound 3, concentration for 50% growth inhibition: 28000 nM
Compound 3: middle estimate off by 1.1-fold (0.05 log units), on the low side, and the stated range covers the measured number.
By their numbers in this assay, from the lowest: compounds 1, 3 and 2 (each within the scatter of the next).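

In this assay, the exchange of 4-bromophenyl for 4-chlorophenyl gives a 1.2-fold higher number from compound 1 to compound 3 (0.07 log units; within the scatter), so at this aromatic carbon, para to a large group, the two halogens cannot be set in order. Within this set, the number therefore does not register the change from bromo to chloro at this position. Nothing available explains this result. Going by these compounds, whether an amine, a carboxylic acid or a methoxy group at this position would shift the number beyond the scatter remains open. So does the effect of removing the halogen altogether.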